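A few compounds are considered here, and "the series" means these few. Any claim that something is new, unique, unknown or untested is made for them only; others in the source may bear on it.

Measured so far in a functional assay on SW-620 cells (Homo sapiens); a higher number here means a weaker inhibitor of growth, a lower number a stronger inhibitor of growth:
- compound 1 `CC(C)(C)c1cc(/C=C/S(=O)(=O)Cc2ccc(Nc3ncnc4ccccc34)cc2)cc(C(C)(C)C)c1O` gives 9000 nM
- compound 2 `O=S(=O)(/C=C/c1ccc(Cl)cc1)Cc1ccc(Nc2ncnc3ccccc23)cc1` gives 77000 nM

Of the two, compound 2 has the higher number and is thus the weaker inhibitor of growth, and its gap to compound 1 lies beyond the scatter. Compound 3 `O=S(=O)(/C=C/c1ccc(C(F)(F)F)cc1F)Cc1ccc(Nc2ncnc3ccccc23)cc1` has not yet been measured in this assay and differs from compound 2 in one place. It carries 2-fluoro-4-(trifluoromethyl)phenyl in place of 4-chlorophenyl on a double-bonded chain carbon bound to a double-bonded chain carbon. Among the measured compounds shown here, no step between measured compounds shows what an exchange of this kind does, so the data offer no direct guide, and compound 2 at 77000 nM remains the only close reference. The expected change is therefore modest, slightly towards a lower number and not beyond the scatter, and the estimated 1.5-fold lower number from compound 2 to compound 3 (0.19 log units; within the scatter) carries wide uncertainty. The estimate for compound 3 is 50000 nM with 15000 nM to 100000 nM as its expected range.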

Compound 3, concentration for 50% growth inhibition: 100000 nM
Estimate against measurement, compound 3: 2.0-fold (0.30 log units) below; measured number inside the range.
By their numbers in this assay, from the lowest: compound 1; then compounds 2 and 3 (each within the scatter of the next).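

In this assay, among the compounds shown here, putting 2-fluoro-4-(trifluoromethyl)phenyl in place of 4-chlorophenyl on a double-bonded chain carbon bound to a double-bonded chain carbon gives a 1.3-fold higher number from compound 2 to compound 3 (0.11 log units; within the scatter) and is the first exchange at this place that can be read as a single step. The entering group has 11 heavy atoms against 7 and carries fluorine instead of chlorine, yet at this place, and on this one pair, the two groups cannot be told apart in this read-out. Nothing available bears on why the two compounds read alike.

What the compounds shown leave open is whether any single exchange at this place can produce a step beyond the scatter, since this pair is the only one for which a step is printed. As far as these compounds go, it also remains open how the shared core would respond to an amine or a carboxylic acid on the ring in place of these halogen-bearing groups, and whether either would give a number different from those of compound 2 and compound 3.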